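The source may report more compounds than this note shows. Statements on the series, on what has been measured and on what is new or still open speak of the compounds shown alone.

Of the compounds shown here, three sharing one core have been measured in a functional assay (aorta) with Rattus norvegicus as the target; a lower number here means that less compound is needed, a higher number that more compound is needed for the effect. Compound 1 `COc1ccc(-c2nc(N=C(N)N)sc2-c2ccc(OC)cc2)cc1` gives 2 uM. Compound 2 `COc1ccc(-c2nc(/N=C(\N)NC(C)C)sc2-c2ccc(OC)cc2)cc1` gives 9.1 uM, so there is a 4.6-fold higher number from compound 1 to compound 2 (0.66 log units; beyond the scatter). Compound 3 `COc1ccc(-c2nc(CN(C)C)sc2-c2ccc(OC)cc2)cc1` gives 8.4 uM and stands second highest of the three: it sits nearest to compound 2, with a 1.1-fold lower number from compound 2 to compound 3 (0.03 log units; within the scatter), and furthest from compound 1, with a 4.2-fold higher number from compound 1 to compound 3 (0.62 log units; beyond the scatter).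

Compound 4 `COc1ccc(-c2nc(CCC(=O)O)sc2-c2ccc(OC)cc2)cc1` has not yet been measured. It differs from compound 3 by carboxymethyl in place of dimethylamino on a saturated chain carbon bound to an aromatic carbon. Among the measured compounds shown here, the two steps that touch the same aromatic carbon, a 4.2-fold higher number from compound 1 to compound 3 (0.62 log units; beyond the scatter) and a 1.1-fold lower number from compound 2 to compound 3 (0.03 log units; within the scatter), show that exchanging the group there can move this assay modestly or leave it within the scatter, but neither step puts a carboxymethyl group in place; no measured step bears directly on this change. A modest rise is expected rather than a fall, with wide uncertainty, as a 1.8-fold higher number from compound 3 to compound 4 (0.25 log units; within the scatter). Compound 4 is therefore estimated at 15 uM, within a range from 4 uM to 60 uM.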

Compound 4, concentration for half-maximal effect: > 100 uM
Compound 4: a limit, no number; the forecaster's own chance of this, stated with the estimate: 15%; middle value at least 6.6-fold (0.82 log units) from the limit.
By their numbers in this assay, from the lowest: compound 1; then compounds 3 and 2 (each within the scatter of the next). At a limit, above all of these: compound 4.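

In this assay compound 4 carries a limit and not a number: the limit of > 100 uM in this assay, at which 1 of the 4 values shown sits.

Carboxymethyl in place of dimethylamino on a saturated chain carbon bound to an aromatic carbon gives an at least 11-fold higher number from compound 3 to compound 4 (1.07 log units; beyond the scatter), whereas the earlier exchanges at this place stayed modest or within the scatter, so a change here can move the read-out much further than those steps showed. The other two steps are also large, an at least 10-fold higher number from compound 2 to compound 4 (1.04 log units; beyond the scatter) and an at least 50-fold higher number from compound 1 to compound 4 (1.69 log units; beyond the scatter), which sets the group without nitrogen apart from all three groups that carry nitrogen.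

On these data alone, the true size of these steps stays open, as they rest on a limit. The compounds shown also leave open whether the carboxylic acid itself or the absence of an amine decides the outcome, and whether an ester, an amide or a longer chain ending in a carboxylic acid would behave the same way.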